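Four related amides and how much cultured cells tolerate

The source may report more compounds than this note shows. Statements on the series, on what has been measured and on what is new or still open speak of the compounds shown alone.

Three measured compounds share one core and differ only in the group on an amide-type nitrogen or in configuration. Compound 1 `CC(C)C[C@H](NC(=O)[C@]1(Cc2ccccc2)CCN1C(=O)OCc1ccccc1)C(N)=O` gives 50000 nM in an ADME assay on HELF cells (Homo sapiens) for cytotoxicity, with a stated time of 3 days; a lower number here means that less compound is tolerated, a higher number that more compound is tolerated. Compound 2 `C[C@H](NC(=O)[C@]1(Cc2ccccc2)CCN1C(=O)OCc1ccccc1)C(=O)NC1CCCCC1` gives only a limit in this assay, namely > 100000 nM. Compound 3 `C[C@H](NC(=O)[C@@]1(Cc2ccccc2)CCN1C(=O)OCc1ccccc1)C(=O)NC1CCCCC1` gives 46000 nM in this assay. Compounds 2 and 3 have the same atoms and bonds: the two compounds have the same atoms and bonds and differ only in configuration as drawn: 1 of 2 stereo elements differ; a stereocentre at a saturated ring carbon is drawn S in compound 2 and R in compound 3, and this gives an at least 2.1-fold lower number from compound 2 to compound 3 (0.33 log units; beyond the scatter). Between compounds 2 and 1 the change is 1-carbamoyl-3-methylbutyl in place of 1-(cyclohexylcarbamoyl)ethyl on an amide-type nitrogen, which gives an at least 2.0-fold lower number from compound 2 to compound 1 (0.30 log units; that floor lies within the scatter). The same change now leads from compound 3 to compound 4 `CC(C)C[C@H](NC(=O)[C@@]1(Cc2ccccc2)CCN1C(=O)OCc1ccccc1)C(N)=O`: 1-carbamoyl-3-methylbutyl in place of 1-(cyclohexylcarbamoyl)ethyl on an amide-type nitrogen. A small step is expected, a 1.2-fold lower number from compound 3 to compound 4 (0.06 log units; within the scatter), because compound 1 gives 50000 nM and compound 3 gives 46000 nM. Compound 4 is therefore estimated at 40000 nM, expected between 15000 nM and 100000 nM.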

Compound 4, half-maximal cytotoxic concentration: 66000 nM
For compound 4 the middle estimate is 1.7-fold (0.22 log units) below the measured one; the range from low to high includes it.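

On the core of compound 3, putting 1-carbamoyl-3-methylbutyl in place of 1-(cyclohexylcarbamoyl)ethyl gives a 1.4-fold higher number from compound 3 to compound 4 (0.16 log units; within the scatter) in this assay, and a change of configuration at one saturated ring carbon alone gives a 1.3-fold higher number from compound 1 to compound 4 (0.12 log units; within the scatter). The same group change therefore does not have the same size on the two cores: the same change on two cores in this assay, an at least 2.0-fold lower number (0.30 log units; that floor lies within the scatter) from compound 2 to compound 1 and a 1.4-fold higher number (0.16 log units; within the scatter) from compound 3 to compound 4, at least 2.8-fold (0.45 log units) apart, beyond the scatter of two such steps. As far as these compounds go, compound 2 gives only a limit, so the gap between the two steps is a floor and its full size remains unknown: the limit of > 100000 nM in this assay, at which 1 of the 4 values shown sits.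

The compounds shown leave open what the same change would do on a third core. They also leave open whether a carboxylic acid, an amine or a longer chain on this amide-type nitrogen would follow either step.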